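A few compounds are considered here, and "the series" means these few. Any claim that something is new, unique, unknown or untested is made for them only; others in the source may bear on it.

Measured so far in a physicochemical assay for lipophilicity, measured as octanol-water partition; a higher number here means a more lipophilic compound, a lower number a more polar compound:
- compound 1 `CCCCCCCCc1cn(C/C=C(/C)CCC=C(C)C)nn1`: 6.92
- compound 2 `CCCCCCCCc1cn(C/C=C(/C)CC/C=C(\C)CCC=C(C)C)nn1`: 8.76

In this assay, among the measured compounds shown here, compound 1 holds the lower of the two numbers, at 6.92, and compound 2 is its only neighbour.

The next compound to be measured is compound 3 `CCCCCCCCc1cn(C/C=C(\C)CCC=C(C)C)nn1`. Against compound 1 the change is the two compounds have the same atoms and bonds and differ only in configuration as drawn: 1 of 1 stereo elements differ; a double bond is drawn Z in compound 1 and E in compound 3. No atom leaves and none enters.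

For the measured compounds named here, only one measured step is available, a number 1.84 log units higher from compound 1 to compound 2 (beyond the scatter). It is large and beyond the scatter, but it comes with 3-methylbut-2-en-1-yl in place of hydrogen on a saturated chain carbon bound to a double-bonded chain carbon. Compound 3 gains no such group, so the size of that step does not carry over. Going by the values given here, no measured pair tests a change of drawn configuration alone, which leaves the expectation weakly anchored.

With the same atoms and bonds on both sides, no shift beyond the scatter is expected, and the expected step is no change at the digits printed from compound 1 to compound 3 (within the scatter). For compound 3 the estimated value is 6.92, with an expected range from 6.55 to 7.25.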

Compound 3, partition coefficient: 6.92
Compound 3: the middle estimate sits on the measured number at the digits printed, within the range that was stated.
By their numbers in this assay, from the lowest: compounds 1 and 3 (each within the scatter of the next); then compound 2.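

In this assay, among the compounds shown here, the double bond drawn Z in compound 1 and E in compound 3 gives no change at the digits printed from compound 1 to compound 3 (within the scatter), so this is the first reading of drawn configuration on its own. For the compounds shown here, at this double bond, the switch from Z to E does not register in the partition read-out, which sets it apart from the only earlier step, a number 1.84 log units higher from compound 1 to compound 2 (beyond the scatter), where 3-methylbut-2-en-1-yl enters in place of hydrogen. The pair can be read as a test of this one configuration because nothing else separates the two compounds: the fact that compounds 1 and 3 differ only in the configuration as drawn

On these data alone, whether the same switch would also leave the number in place in compound 2, which carries the added 3-methylbut-2-en-1-yl group, remains open, since that compound has no partner drawn the other way. Also open, as far as these compounds go, is how far the number would move with a carboxylic acid or an amine on the shared core, and whether Z and E forms would still read alike with such a group present.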